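A few compounds are considered here, and "the series" means these few. Any claim that something is new, unique, unknown or untested is made for them only; others in the source may bear on it.

Measured so far in a physicochemical assay for acid dissociation:

Compound 1, `FC(F)(F)c1ccc(-c2ccc3c(NCCCNCc4ccco4)ccnc3c2)cc1`, gives 9.47.
Compound 2, `COc1ccc(-c2ccc3c(NCCCNCc4ccco4)ccnc3c2)cc1`, gives 9.47.
Compound 3, `c1coc(CNCCCNc2ccnc3cc(CC4CCCCC4)ccc23)c1`, gives 9.47.

All three compounds share the same core and the same chain ending in a (furan-2-yl)methyl group; they differ only in the group sitting on an aromatic carbon of the core. Compound 1 stands level with compounds 2 and 3: the step of no change at the digits printed from compound 1 to compound 2 (within the scatter) and the step of no change at the digits printed from compound 1 to compound 3 (within the scatter) both stay within the scatter, as does the step of no change at the digits printed from compound 2 to compound 3 (within the scatter).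

Compound 4, `COc1ccc(F)cc1CNCCCNc1ccnc2cc(-c3ccc(C(F)(F)F)cc3)ccc12`, keeps the 4-(trifluoromethyl)phenyl group of compound 1 and changes the far end of the chain instead:

5-fluoro-2-methoxyphenyl in place of furan-2-yl on a saturated chain carbon bound to an amine nitrogen

Within the data shown here, none of the measured steps touches this part of the molecule; each of them swapped a group on the core and left the value in this assay unchanged. Among the measured compounds shown here, that tells only that the core substituent does not move the number, and gives no direct guide to a change at the chain end. With nothing pointing in either direction, compound 4 is expected to sit close to compound 1, the step of a number 0.03 log units higher from compound 1 to compound 4 (within the scatter) being estimated as small. The estimate for compound 4 is 9.5, with a range from 9 to 10.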

Compound 4, acid dissociation constant: 9.47
Beside the measured number, compound 4's estimate is 0.03 log units above it, within the range that was stated.
By their numbers in this assay, from the lowest: compounds 1, 2, 3 and 4 (each within the scatter of the next).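

In this assay, the swap at the chain end gives no change at the digits printed from compound 1 to compound 4 (within the scatter), so the level reading seen so far now extends beyond the group on the shared core. Among these compounds, the earlier steps varied only that core group, whereas this one replaces a five-membered aromatic ring with 1 hetero atom by a six-membered aromatic ring of carbon only, on a saturated chain carbon bound to an amine nitrogen, and brings in fluorine while the hydrogen-bond acceptor count stays the same. So, for this one pair, a change of ring type and of heavy-atom count at this position goes with no shift beyond the scatter, though nothing shown here gives a reason for that.

Among the compounds shown here, every group at this position so far is an aromatic ring, so it remains open whether a carboxylic acid or a second amine at the end of the chain would also stay level with compound 1. A longer chain between the core and the amine nitrogen, or an amide in place of that amine, is also open, as the compounds shown all keep the same chain and the same amine.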